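This account rests on a few compounds, and the source may have more. Where it says the series, first, only, none or still open, it means among the compounds named here.

Measured so far:
compound 1 `c1ccc(-c2cn3ccnc3c(-c3ccc4ncn(C5CCCCC5)c4c3)n2)cc1` — 29.3%
compound 2 `Brc1ccc(-c2cn3ccnc3c(-c3ccc4ncn(C5CCCCC5)c4c3)n2)cc1` — 5.66%

In a functional assay on DU-145 cells (Homo sapiens) for inhibition, read by sulforhodamine B assay, with a stated time of 48 h, tested at 10 uM (on this read-out higher numbers stand for more inhibition at the one concentration tested (going by the name of the read-out) and lower numbers for less inhibition), compound 1 gives 29.3%, and compound 2 gives 5.66%. For the measured compounds named here, compound 2 stands lowest of the two numbers; its nearest neighbour is compound 1, and the single measured step, a number 23.6 percentage points lower from compound 1 to compound 2 (beyond the scatter), separates them.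

Compound 3 `c1csc(-c2cn3ccnc3c(-c3ccc4ncn(C5CCCCC5)c4c3)n2)c1` is not yet measured. It differs from compound 2 in one place: thiophen-2-yl in place of 4-bromophenyl on an aromatic carbon. Going by the values given here, the only measured step that bears on this change is a number 23.6 percentage points lower from compound 1 to compound 2 (beyond the scatter), where a bromo in place of hydrogen on the same aromatic carbon region went with a modest fall in inhibition. Among the compounds with values here, compound 3 removes the bromine along with the six-membered ring and brings in a five-membered ring with one hetero atom and one hydrogen-bond acceptor, so the change is larger than the single measured step and is only loosely covered by it. Since the bromo-bearing compound 2 sits low and the unsubstituted compound 1 sits higher, a rise back toward the level of compound 1 is expected, with wide uncertainty. The estimated step is a number 16.3 percentage points higher from compound 2 to compound 3 (beyond the scatter). Compound 3 is therefore expected to give about 22%, in a range from 3% to 42%.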

Compound 3, a percentage reported as inhibition, at one concentration (the size of the read-out at that concentration, not a potency): 5.07%
Beside the measured number, compound 3's estimate is 16.9 percentage points above it; low and high end bracket the measured number.
By their numbers in this assay, from the lowest: compounds 3 and 2 (each within the scatter of the next); then compound 1.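

In this assay, thiophen-2-yl in place of 4-bromophenyl on this aromatic carbon goes with a number 0.6 percentage points lower from compound 2 to compound 3 (within the scatter) and so does not separate the two groups, even though they differ in ring size and in the atoms they carry. The step with thiophen-2-yl in place of phenyl, a number 24.2 percentage points lower from compound 1 to compound 3 (beyond the scatter), shows that a group without bromine can stand at the same low level as the 4-bromophenyl of compound 2, so the lower number at this position is not tied to bromine alone, and among the three groups shown, only the plain phenyl of compound 1 stands apart. No evidence is available on why these three groups give these numbers.

What the compounds shown leave open is whether any other group on this aromatic carbon, such as a pyridine ring, an aminomethyl group or a carboxylic acid, would match or pass compound 1 at 29.3% in this assay. They also leave open whether a smaller substituent on the phenyl ring, such as fluoro or methoxy, would lower the number as far as the bromo of compound 2 does.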